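Methoxy for trifluoromethyl in a weakly cytotoxic series

The source may report more compounds than this note shows. Statements on the series, on what has been measured and on what is new or still open speak of the compounds shown alone.

In a functional assay on BT-483 cells (Homo sapiens) for cytotoxicity, read by MTT assay, with a stated time of 24 h (a lower number here means a stronger inhibitor, a higher number a weaker inhibitor), compound 3 `CCNc1cc(-c2ccc(NC(=O)Nc3ccccc3Cl)cc2C(F)(F)F)ccn1` gives 20800 nM and compound 1 `CCNc1cc(-c2ccc(NC(=O)Nc3ccc(C)cc3)cc2C(F)(F)F)ccn1` gives 27100 nM. Swapping the group on the amide-type nitrogen between these two gives a 1.3-fold lower number from compound 1 to compound 3 (0.11 log units; within the scatter), so they cannot be told apart, and compound 3 stands level with compound 1. Compound 2 `CCNc1cc(-c2ccc(NC(=O)Nc3cccc4ccccc34)cc2C(F)(F)F)ccn1` returns only a limit, > 30000 nM. Its step is an at least 1.1-fold higher number from compound 1 to compound 2 (0.04 log units; that floor lies within the scatter).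

Compound 4 `CCNc1cc(-c2ccc(NC(=O)Nc3ccccc3Cl)cc2OC)ccn1` keeps the 2-chlorophenyl of compound 3 but has methoxy in place of trifluoromethyl on an aromatic carbon, ortho to a 2-(ethylamino)pyridin-4-yl group: methoxy in place of trifluoromethyl on an aromatic carbon. Going by the values given here, all the measured steps change the group on the amide-type nitrogen, and none touches this place, so they give no direct guide to the size or direction of this step. No shift beyond the scatter is therefore expected, though with real uncertainty in either direction. The expected step is a 1.0-fold lower number from compound 3 to compound 4 (0.02 log units; within the scatter). For compound 4 the estimated value is 20000 nM, with an expected range of 8000 nM to 30000 nM.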

Compound 4, half-maximal inhibitory concentration: > 30000 nM
Compound 4 was reported as a limit; the forecaster's own chance of this, stated with the estimate: 25%; at least 1.5-fold (0.17 log units) between middle value and limit.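

In this assay compound 4 gives > 30000 nM, which is a limit and not a number. Methoxy in place of trifluoromethyl, ortho to a 2-(ethylamino)pyridin-4-yl group, gives an at least 1.4-fold higher number from compound 3 to compound 4 (0.15 log units; that floor lies within the scatter); this is the first step shown at this position, and it offers no sign of a lower number with methoxy. The true size of the step cannot be read, because the reading stops at the edge of what the assay reports: the limit of > 30000 nM in this assay, at which 2 of the 4 values shown sit.

The compounds shown leave open whether another group at this position, such as an amine or a nitrile, would give a lower number than trifluoromethyl. They also leave open whether methoxy would act the same way with 4-methylphenyl or naphthalen-1-yl on the amide-type nitrogen in place of 2-chlorophenyl.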